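From Compound 3 to Compound 4: Adding 2-Phenylethenyl

A few compounds are considered here, and "the series" means these few. Any claim that something is new, unique, unknown or untested is made for them only; others in the source may bear on it.

In a functional assay on HCT-116 cells (Homo sapiens) for cytotoxicity, read by resazurin assay, with a stated time of 72 h (a higher number here means a weaker inhibitor, a lower number a stronger inhibitor), compound 3 `COCOc1cc(OC)cc(OC)c1C(C)=O` gives > 20000 nM, a limit of the assay and not a number. Compound 4 `COCOc1cc(OC)cc(OC)c1C(=O)/C=C/c1ccccc1` has 2-phenylethenyl in place of methyl on a carbonyl carbon.

Among the measured compounds shown here, no measured step covers this change directly, but compound 1 and compound 2 offer indirect evidence because both already carry 2-phenylethenyl. Compound 1 `COc1cc(OC)c(C(=O)/C=C/c2ccccc2)c(OC)c1` gives > 20000 nM, also a limit and not a number. Compound 2 `COc1cc(OC)c(C(=O)/C=C/c2ccccc2)c(OC)c1Cc1ccccc1O` gives 18600 nM in this assay. For the measured compounds named here, the only measured step, an at least 1.0-fold lower number from compound 1 to compound 2 (0.03 log units; that floor lies within the scatter), stays within the scatter. Going by the values given here, the series so far rests largely on (the limit of > 20000 nM in this assay, at which 2 of the 3 values shown sit).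

Neither compound therefore points to a marked gain in this assay from a structure bearing 2-phenylethenyl, so no step beyond the scatter is expected, in either direction. The expected step is a step that the limit leaves unreadable from compound 3 to compound 4. For compound 4 the estimated value is 22000 nM, with an expected range of 9000 nM to 40000 nM.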

Compound 4, half-maximal inhibitory concentration: > 20000 nM
Compound 4: no number, only a limit; the forecaster's own chance of this, stated with the estimate: 70%; the middle value lies beyond the limit too.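

In this assay compound 4 gives a limit and not a number (> 20000 nM). No new step can be read from compound 3 or compound 1 to compound 4, as the series sits largely at one limit: (the limit of > 20000 nM in this assay, at which 3 of the 4 values shown sit). As far as these compounds go, whether 2-phenylethenyl in place of methyl on a carbonyl carbon changes the read-out stays open.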